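Swapping Methoxy for Chloro on the Aryl Urea

The source may report more compounds than this note shows. Statements on the series, on what has been measured and on what is new or still open speak of the compounds shown alone.

Three ureas have been measured in an ADME assay on the whole organism with Oryza sativa as the target, tested at 10 uM; on this read-out higher numbers stand for a weaker effect at the one concentration tested and lower numbers for a stronger effect. Compound 1, `C[C@H](NC(=O)Nc1ccccc1C(C)(C)C)c1ccccc1`, gives 100% in this assay. Compound 2, `C[C@H](NC(=O)Nc1ccccc1C(F)(F)F)c1ccccc1`, gives 97% in this assay. Compound 3, `COc1ccccc1NC(=O)N[C@@H](C)c1ccccc1`, gives 95% in this assay. The three differ only in the group carried on one aromatic carbon of the shared core, and the steps between them are all small: a number 3 percentage points lower from compound 1 to compound 2 (within the scatter), a number 5 percentage points lower from compound 1 to compound 3 (within the scatter), and a number 2 percentage points lower from compound 2 to compound 3 (within the scatter). Compound 3 therefore stands within the usual scatter of the other two, and nothing separates the three numbers from one another.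

Compound 4, `C[C@H](NC(=O)Nc1ccccc1Cl)c1ccccc1`, has not yet been measured. Its change from compound 3 is chloro in place of methoxy on an aromatic carbon. All three measured steps exchange one group for another on this same aromatic carbon, and none of them moved the read-out beyond the scatter. The change leading to compound 4 is of the same kind, so no step beyond the scatter is expected here either. The expected step is no change at the digits printed from compound 3 to compound 4 (within the scatter). Compound 4 is estimated to give 95% in this assay, with a range from 85% to 100%.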

Compound 4, a percentage reported as activity, at one concentration (the size of the read-out at that concentration, not a potency): 106%
For compound 4 the middle estimate is 11 percentage points below the measured one; the whole stated range lies below it.
By their numbers in this assay, from the lowest: compounds 3, 2, 1 and 4 (each within the scatter of the next, the first and the last beyond it).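

In this assay, for the compounds shown here, this aromatic carbon, ortho to a large group, turns out not to be fully indifferent to what it carries: chloro in place of methoxy gives a number 11 percentage points higher from compound 3 to compound 4 (beyond the scatter) and is the first exchange here to leave the usual scatter. Yet the chloro compound is separated only from the methoxy compound, since the comparison with trifluoromethyl gives a number 9 percentage points higher from compound 2 to compound 4 (within the scatter) and the comparison with tert-butyl gives a number 6 percentage points higher from compound 1 to compound 4 (within the scatter) and neither of these steps is beyond the scatter, so the position shows one modest difference between two particular groups and no clear ranking of all four. Nothing available here bears on what lies behind this step.

On these data alone, it stays open where an amine, a hydroxyl or a bromo on this same aromatic carbon would fall relative to the methoxy and chloro compounds, and whether any of them would move the read-out further than this modest step. Also open, as far as these compounds go, is whether methoxy and chloro would differ in the same way on a core other than the shared one, or at any concentration other than the single one tested.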